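Swapping Cyclopropyl for Furanylmethyl at the Assay Limit

The source may hold more compounds than are shown below. What is called first, only, known or untested is meant among the compounds shown, and "the series" means these compounds.

Compound 1, `C(=C/c1nc(Nc2ccccc2)c2sccc2n1)\c1ccccc1`: in a functional assay on L02 cells (Homo sapiens) for inhibition, read by Griess assay, with stated times of 1 h and 24 h (a higher number here means a weaker inhibitor, a lower number a stronger inhibitor), compound 1 gives > 1000000 nM.
Compound 2, `Fc1ccc(CNc2nc(/C=C/c3ccco3)nc3ccsc23)cc1`: in this assay compound 2 gives > 1000000 nM.
Compound 3, `COc1cc(/C=C/c2nc(NC3CC3)c3sccc3n2)cc(OC)c1OC`: in this assay compound 3 gives > 1000000 nM.

The value of compound 1 is a limit of the assay, not a number. The same holds for compound 2, whose value is a limit. For compound 3 as well, only a limit is known, not a measured number. The whole picture is the limit of > 1000000 nM in this assay, at which 3 of the 3 values shown sit. Every value is a limit. Within the data shown here, compound 3 therefore cannot be placed above or below the other two, and no step between any pair of measured compounds can be given.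

Compound 4, `COc1cc(/C=C/c2nc(NCc3ccco3)c3sccc3n2)cc(OC)c1OC`, differs from compound 3 in one place: (furan-2-yl)methyl in place of cyclopropyl on a nitrogen on an aromatic ring. The change replaces a small ring of carbon only with a five-membered aromatic ring carrying one hetero atom, on the nitrogen attached to the shared core.

Among the measured compounds shown here, with no measured step to lean on, and with compound 3 itself sitting at a limit, no shift in this assay beyond the usual scatter is expected from this change. The step of a number no higher from compound 3 to compound 4 (the limit leaves the size open) is therefore estimated as none beyond the scatter. For compound 4 in this assay the expected half-maximal inhibitory concentration is 1000000 nM, in a range from 300000 nM to 3000000 nM, with the most likely outcome being that the assay again reports only a limit.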

Compound 4, half-maximal inhibitory concentration: 189000 nM
Compound 4: middle estimate off by 5.3-fold (0.72 log units), on the high side, outside the stated range (below it).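

In this assay, among these compounds, (furan-2-yl)methyl in place of cyclopropyl on a nitrogen on an aromatic ring gives an at least 5.2-fold lower number from compound 3 to compound 4 (0.72 log units; beyond the scatter), so a change at this one place can bring a compound of this series into the range where the assay reports a number, something that none of the earlier compounds could show. The value of compound 3, > 1000000 nM, is a limit of the assay and not a number. Compound 4 is therefore the only compound here with a measured value, and the rest of the picture remains the limit: the limit of > 1000000 nM in this assay, at which 3 of the 4 values shown sit.

Steps among compound 1, compound 2 and compound 3 cannot be read, so the series still offers only this single comparison, and it cannot separate the part played by the furan ring from that of the carbon linking it to the nitrogen. Going by these compounds, it also remains open whether a (thiophen-2-yl)methyl group or a plain butyl chain on that same nitrogen would give a measured value, and how such a value would compare with that of compound 4.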